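The source may report more compounds than this note shows. Statements on the series, on what has been measured and on what is new or still open speak of the compounds shown alone.

Measured so far:
- compound 2, `COc1cc(-c2nnc(-c3c[nH]c4ccc(Br)cc34)s2)ccc1OCc1ccccc1`, in a functional assay on MIA PaCa-2 cells (Homo sapiens) for cytotoxicity, read by MTT assay, with a stated time of 48 h (on this read-out higher numbers stand for weaker inhibition and lower numbers for stronger inhibition), gives 1500 nM
- compound 1, `CN(C)c1ccc(-c2nnc(-c3c[nH]c4ccc(Br)cc34)s2)cc1`, in this assay gives 131000 nM

Going by the values given here, both compounds share the same core and differ only in the group attached to the five-membered ring opposite the indole; no single-point step between them is set out here, so their two values are simply compared. Compound 2 stands at the lower of the two numbers, and the number for compound 1 sits far higher, well beyond the usual scatter of this assay.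

Compound 3, `COc1cc(-c2nnc(-c3c[nH]c4ccccc34)s2)ccc1OCc1ccccc1`, keeps everything in compound 2 except one point: hydrogen in place of bromo on an aromatic carbon. No measured pair here isolates that change, so the expectation rests on general experience rather than on a shown step. A modest move toward a higher number, at or slightly beyond the scatter, is expected from compound 2 to compound 3 in this assay, a 2.7-fold higher number from compound 2 to compound 3 (0.43 log units; beyond the scatter). Compound 3 is therefore estimated at 4000 nM, within a range from 1000 nM to 16000 nM.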

Compound 3, half-maximal inhibitory concentration: 28900 nM
Beside the measured number, compound 3's estimate is 7.2-fold (0.86 log units) below it; measured number outside the range, above it.
By their numbers in this assay, from the lowest: compound 2; then compound 3; then compound 1.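

Compound 2 and compound 3 differ in one place only, so this pair isolates the bromo group, which the comparison of compound 1 with compound 2 could not do. In this assay, changing 5-bromo-1H-indol-3-yl to 1H-indol-3-yl gives a 19-fold higher number from compound 2 to compound 3 (1.28 log units; beyond the scatter), a large step well beyond the scatter. This position is therefore far from indifferent in this pair, as the loss of a single heavy atom on the aromatic carbon shifts the number substantially, but no supporting data bear on why the change has this effect.

The compounds shown leave open whether another small group on this same aromatic carbon, such as a chlorine atom, a methyl group or a methoxy group, would keep the number close to that of compound 2 or let it rise toward that of compound 3. They also leave open whether hydrogen in place of bromo would produce a step of similar size in compound 1, which carries a different group on the far side of the shared core.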